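The source may hold more compounds than are shown below. What is called first, only, known or untested is meant among the compounds shown, and "the series" means these compounds.

In a functional assay on HEK293 cells for antagonist activity at transient receptor potential cation channel subfamily V member 1 (Homo sapiens), read by FLIPR and calcium flux (a lower number here means a stronger inhibitor, a higher number a weaker inhibitor), compound 1 `FC(F)(F)c1ccc(Nc2nc(N3CCN(C4CCC4)CC3)nc3c2CCN(c2ncccc2C(F)(F)F)CC3)cc1` gives 24 nM and compound 2 `CCC(CC)N1CCN(c2nc3c(c(Nc4ccc(C(F)(F)F)cc4)n2)CCN(c2ncccc2C(F)(F)F)CC3)CC1` gives 41 nM, and the step of a 1.7-fold higher number from compound 1 to compound 2 (0.23 log units; within the scatter) stays within the scatter. Compound 3 `FC(F)(F)c1ccc(Nc2nc(NC3CCCNC3)nc3c2CCN(c2ncccc2C(F)(F)F)CC3)cc1` reaches only a limit of this assay, > 5000 nM, so no exact number is known for it. Within the data shown here, it is the one compound sitting at the limit of > 5000 nM in this assay, at which 1 of the 3 values shown sits, at the weak end of the three. The steps of an at least 200-fold higher number from compound 1 to compound 3 (2.31 log units; beyond the scatter) and an at least 120-fold higher number from compound 2 to compound 3 (2.08 log units; beyond the scatter) show how much (piperidin-3-yl)amino on the aromatic carbon lost. Compound 4 `CNC1CCN(c2nc3c(c(Nc4ccc(C(F)(F)F)cc4)n2)CCN(c2ncccc2C(F)(F)F)CC3)C1` alters that very group: 3-(methylamino)pyrrolidin-1-yl in place of (piperidin-3-yl)amino on an aromatic carbon, so the attachment again runs through a ring of the group, as with the 4-cyclobutylpiperazin-1-yl of compound 1. A partial recovery is therefore expected, and compound 4 is estimated at 400 nM (from 60 nM to 3000 nM). That estimate means an expected step of an at least 12-fold lower number from compound 3 to compound 4 (1.09 log units; beyond the scatter), though with compound 3 only a limit its size is uncertain.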

Compound 4, half-maximal inhibitory concentration in the transient receptor potential cation channel subfamily V member 1 assay: 2790 nM
For compound 4 the middle estimate is 7.0-fold (0.84 log units) below the measured one; measured number inside the range.
By their numbers in the transient receptor potential cation channel subfamily V member 1 assay, from the lowest: compounds 1 and 2 (each within the scatter of the next); then compound 4. At a limit, above all of these: compound 3.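

Running the attachment through a ring of the group does not by itself restore activity: in the transient receptor potential cation channel subfamily V member 1 assay, a 68-fold higher number from compound 2 to compound 4 (1.83 log units; beyond the scatter) and a 120-fold higher number from compound 1 to compound 4 (2.07 log units; beyond the scatter). Compound 3 gives only a limit of this assay: the limit of > 5000 nM in the transient receptor potential cation channel subfamily V member 1 assay, at which 1 of the 4 values shown sits. In the transient receptor potential cation channel subfamily V member 1 assay the change is an at least 1.7-fold lower number from compound 3 to compound 4 (0.25 log units; that floor lies within the scatter), and that figure is only a floor. In a physicochemical assay for solubility, in simulated intestinal fluid, measured as thermodynamic solubility, at pH 6.8 (a lower number here means a less soluble compound, a higher number a more soluble compound), compound 3 gives 203 ug/mL and compound 4 gives 233 ug/mL, two values within the usual scatter of each other.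

Whether the five-membered ring or the free methylamino group accounts for the gap to compounds 1 and 2 stays open. A 3-(dimethylamino)pyrrolidin-1-yl or 4-methylpiperazin-1-yl group here could help separate the two.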